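A Smaller, Polar Group Replaces Cyclobutyl on the Shared Core

The source may report more compounds than this note shows. Statements on the series, on what has been measured and on what is new or still open speak of the compounds shown alone.

Of the compounds shown here, three built on one shared core have been measured in an assay on isolated protein for binding affinity to adenosine receptor A1 (Bos taurus); on this read-out higher numbers stand for weaker inhibition and lower numbers for stronger inhibition. Compound 1 `Clc1ccccc1Cn1nnc2c(NC3CCC3)nc(-c3ccccc3)nc21` gives 24000000 nM, the highest of the three numbers and thus the weakest binding seen so far. Compound 2 `c1ccc(Cn2nnc3c(NC4CC4)nc(-c4ccccc4)nc32)cc1` gives 11000000 nM, and compound 3 `c1ccc(Cn2nnc3c(NC4CCC4)nc(-c4ccccc4)nc32)cc1` gives 5000000 nM, the lowest of the set.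

Two steps connect these numbers. Removing the chloro from the aromatic carbon gave a 4.8-fold lower number from compound 1 to compound 3 (0.68 log units; beyond the scatter), and exchanging the group on the ring nitrogen gave a 2.2-fold lower number from compound 2 to compound 3 (0.34 log units; beyond the scatter). Both are modest but real.

Compound 4 `OCCNc1nc(-c2ccccc2)nc2c1nnn2Cc1ccccc1Cl` keeps the chloro of compound 1 and changes only the group on the ring nitrogen: 2-hydroxyethyl in place of cyclobutyl on a nitrogen on an aromatic ring. Going by the values given here, no measured step covers this exact exchange. Among the compounds with values here, the only comparable step, cyclopropyl to cyclobutyl, shows that this position shifts binding by a small amount, so a step of similar size, in either direction, would be in keeping with what is known; the chloro that weakened compound 1 remains in place.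

Compound 4 is therefore expected to stay close to compound 1, with an estimated step of a 1.3-fold higher number from compound 1 to compound 4 (0.10 log units; within the scatter), giving an expected value of 30000000 nM within a range from 8000000 nM to 100000000 nM.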

Compound 4, inhibition constant: 116000000 nM
For compound 4 the middle estimate is 3.9-fold (0.59 log units) below the measured one; measured number above the stated range.
By their numbers in this assay, from the lowest: compound 3; then compound 2; then compound 1; then compound 4.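

In this assay, the position on the nitrogen turns out to be more sensitive than the cyclopropyl and cyclobutyl pair suggested: the new step is a clear move toward weaker binding (a 4.8-fold higher number from compound 1 to compound 4 (0.68 log units; beyond the scatter)), larger in its printed numbers than the step between those two rings (a 2.2-fold lower number from compound 2 to compound 3 (0.34 log units; beyond the scatter)). Going by these compounds alone, it is also the first change at this position that leaves carbon rings behind, and it matches in size the effect of removing the chloro (a 4.8-fold lower number from compound 1 to compound 3 (0.68 log units; beyond the scatter)), so the group on this nitrogen matters as much to the number as that chloro does. Nothing measured here explains why the number rose.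

The exchange removes the four-membered ring and brings in an oxygen-bearing chain in a single step, so the compounds shown cannot separate the two changes. A plain ethyl group or a 2-methoxyethyl group at this position would help to tell them apart, and 2-hydroxyethyl on the core without the chloro would show whether the same step holds there.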